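A few compounds are considered here, and "the series" means these few. Any claim that something is new, unique, unknown or untested is made for them only; others in the source may bear on it.

Compound 3 `O=S(=O)(c1ccc(F)c(F)c1)c1cnc2cc(F)ccc2c1-c1cccc(F)c1` gives 0.6 mL/min in an ADME assay on microsomes from liver (Homo sapiens) for metabolic stability, tested at 2.5 uM; a lower number here means slower removal, a higher number faster removal of the compound. Among the three compounds measured it holds the second highest number. Compound 1 `COc1ccc(-c2c(S(=O)(=O)c3ccc(F)c(F)c3)cnc3cc(F)ccc23)cc1` gives 1.1 mL/min in this assay; the step of a 1.8-fold lower number from compound 1 to compound 3 (0.26 log units; within the scatter). Compound 2 `O=S(=O)(c1ccc(F)c(F)c1)c1cnc2cc(F)ccc2c1-c1ccc(Cl)cc1` gives 0.01 mL/min in this assay; the step of a 60-fold higher number from compound 2 to compound 3 (1.78 log units; beyond the scatter). The remaining step, a 110-fold lower number from compound 1 to compound 2 (2.04 log units; beyond the scatter), separates the two ends of the set.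

Compound 4 `O=S(=O)(c1cc(Cl)cc(Cl)c1)c1cnc2cc(F)ccc2c1-c1cccc(F)c1` differs from compound 3 in one place: 3,5-dichlorophenyl in place of 3,4-difluorophenyl on a sulfonyl sulfur. For the measured compounds named here, none of the measured steps touches the group on the sulfonyl sulfur; all three concern the aryl group on the shared core. Going by the values given here, they show only that one change of a substituent on an aromatic carbon can shift this assay by a large amount, as in a 110-fold lower number from compound 1 to compound 2 (2.04 log units; beyond the scatter), or leave it within the scatter, as in a 1.8-fold lower number from compound 1 to compound 3 (0.26 log units; within the scatter). Among the compounds with values here, with no direct precedent, a step within the scatter is expected for compound 4, a 1.2-fold lower number from compound 3 to compound 4 (0.08 log units; within the scatter), but with a wide range. Compound 4 is estimated at 0.5 mL/min, from 0.1 mL/min to 2.5 mL/min.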

Compound 4, intrinsic clearance in a liver preparation (reported as CLH), per the amount of preparation that the assay uses: 0.41 mL/min
Compound 4: the middle estimate sits 1.2-fold (0.09 log units) above what was measured, within the range that was stated.
By their numbers in this assay, from the lowest: compound 2; then compounds 4, 3 and 1 (each within the scatter of the next, the first and the last beyond it).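

The group on the sulfonyl sulfur now has its first measured change: 3,5-dichlorophenyl in place of 3,4-difluorophenyl gives a 1.5-fold lower number from compound 3 to compound 4 (0.17 log units; within the scatter) in this assay. With 3-fluorophenyl held on the shared core, this exchange of one dihalophenyl group for another leaves the read-out within the scatter, in contrast to the large change at the aryl group on the core, a 110-fold lower number from compound 1 to compound 2 (2.04 log units; beyond the scatter). Nothing available explains this result.

Going by these compounds, both groups seen on the sulfonyl sulfur are dihalophenyl rings, so what an amine, a carboxylic acid or a longer alkyl chain would do in that place remains open. Also open, on these data alone, is whether the exchange stays this small with 4-chlorophenyl or 4-methoxyphenyl on the shared core in place of 3-fluorophenyl.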